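This account rests on a few compounds, and the source may have more. Where it says the series, first, only, none or still open, it means among the compounds named here.

Compound 1 `Cc1c(C(=O)Nc2ccccc2F)cnn1-c1ccc(F)cc1` gives 4000 nM in a functional assay with Homo sapiens as the target; a higher number here means a weaker inhibitor, a lower number a stronger inhibitor. Compound 2 `Cc1ccccc1NC(=O)c1cnn(-c2ccc(F)cc2)c1C` differs from it only by methyl in place of fluoro on an aromatic carbon, and in this assay compound 2 gives 1100 nM; that change made a 3.6-fold lower number from compound 1 to compound 2 (0.56 log units; beyond the scatter). Compound 3 `Cc1c(C(=O)Nc2ccc(C(F)(F)F)cc2)cnn1-c1cccc(F)c1` carries a different core, and the difference between the two cores is not broken down here. In this assay compound 3 gives 3100 nM, a number that stands within the scatter of compound 1. Compound 4 `Cc1cccc(-n2ncc(C(=O)Nc3ccc(C(F)(F)F)cc3)c2C)c1` has not yet been measured; it differs from compound 3 by methyl in place of fluoro on an aromatic carbon. This is the same kind of change as the earlier one, but there the group sat ortho to a large group, while here it sits meta to a large group. Compound 4 is expected to show a 2.1-fold lower number from compound 3 to compound 4 (0.32 log units; beyond the scatter), a somewhat smaller step than the earlier one because a 3.6-fold lower number from compound 1 to compound 2 (0.56 log units; beyond the scatter) was made at a different place on the ring. Compound 4 is therefore estimated at 1500 nM, within 700 nM to 3500 nM.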

Compound 4, half-maximal inhibitory concentration: 2500 nM
Beside the measured number, compound 4's estimate is 1.7-fold (0.22 log units) below it; measured number inside the range.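

Carried to a second core, methyl in place of fluoro gave a 1.2-fold lower number from compound 3 to compound 4 (0.09 log units; within the scatter) in this assay, so the step seen on the first core did not keep its size. The two steps differ by more than their scatter: the same change on two cores in this assay, a 3.6-fold lower number (0.56 log units; beyond the scatter) from compound 1 to compound 2 and a 1.2-fold lower number (0.09 log units; within the scatter) from compound 3 to compound 4, 2.9-fold (0.47 log units) apart, beyond the scatter of two such steps. This shows that the change cannot be carried from one core to the other at a fixed size, but it does not show whether the core itself or the place of the change on the ring sets the difference, and two pairs give no rule for the series.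

On these data alone, it remains open whether the 3-fluorophenyl to 3-methylphenyl change would give a similar step on the first core. As far as these compounds go, how a chloro or methoxy group at that place would read in this assay also remains open.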